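Quinazoline Series: An Isopropylamino Analogue of Compound 3

The source may hold more compounds than are shown below. What is called first, only, known or untested is meant among the compounds shown, and "the series" means these compounds.

Measured compounds:
compound 1, `COCc1nc(Nc2ccc(C(F)(F)F)cc2)c2ccc(-c3ncccc3C(F)(F)F)cc2n1` — 1.5 nM
compound 2, `CC(C)OCc1nc(Nc2ccc(C(F)(F)F)cc2)c2ccc(-c3ncccc3C(F)(F)F)cc2n1` — 0.3 nM
compound 3, `CS(=O)(=O)CCc1nc(Nc2ccc(C(F)(F)F)cc2)c2ccc(-c3ncccc3C(F)(F)F)cc2n1` — 36 nM

The three measured compounds share one core and differ only in the side chain on the saturated carbon bound to the aromatic carbon. In a functional assay for antagonist activity at transient receptor potential cation channel subfamily V member 1 (Homo sapiens) (a higher number here means a weaker inhibitor, a lower number a stronger inhibitor), compound 3 gives the highest number of the three, with compound 1 nearest and compound 2 furthest, as shown by a 24-fold higher number from compound 1 to compound 3 (1.38 log units; beyond the scatter) and a 120-fold higher number from compound 2 to compound 3 (2.08 log units; beyond the scatter). Among the ethers, compound 2 is also set apart from compound 1, as a 5.0-fold lower number from compound 1 to compound 2 (0.70 log units; beyond the scatter) shows.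

The unmeasured compound 4, `CC(C)NCc1nc(Nc2ccc(C(F)(F)F)cc2)c2ccc(-c3ncccc3C(F)(F)F)cc2n1`, differs from compound 3 by isopropylamino in place of (methylsulfonyl)methyl on a saturated chain carbon bound to an aromatic carbon. The steps from the ethers to the sulfone both bear on this change, and both were large. Compound 4 carries an isopropyl group on a single heteroatom, as compound 2 does, rather than the sulfone of compound 3, so the number is expected to move back toward that of compound 2, which gives 0.3 nM, though not necessarily all the way. A large downward step is therefore expected in this assay, estimated as an 18-fold lower number from compound 3 to compound 4 (1.26 log units; beyond the scatter). Compound 4 is thus expected to give about 2 nM in this assay, with a range from 0.3 nM to 15 nM.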

Compound 4, half-maximal inhibitory concentration: 35 nM
Beside the measured number, compound 4's estimate is 18-fold (1.24 log units) below it; measured number above the stated range.
By their numbers in this assay, from the lowest: compound 2; then compound 1; then compounds 4 and 3 (each within the scatter of the next).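

Keeping the isopropyl group does not by itself hold the number down at this position: in this assay, isopropylamino in place of isopropoxy gives a 120-fold higher number from compound 2 to compound 4 (2.07 log units; beyond the scatter). The same amine in place of methoxy gives a 23-fold higher number from compound 1 to compound 4 (1.37 log units; beyond the scatter), so among these four compounds the two ethers stand apart from both the amine and the sulfone, a division the earlier compounds could not show. Isopropylamino in place of (methylsulfonyl)methyl gives a 1.0-fold lower number from compound 3 to compound 4 (0.01 log units; within the scatter), so these two side chains, though they differ in heavy atoms and in hydrogen-bond donors, cannot be told apart in this assay. Nothing in the data given accounts for the gap between the ethers and the amine.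

The compounds shown leave open whether the nitrogen itself or the hydrogen on it goes with the higher number, a question that a methyl(isopropyl)amino group or an all-carbon isobutyl chain would bear on. They also leave open whether methylamino would differ from isopropylamino, as the methyl and isopropyl ethers differ from each other.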